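This account rests on a few compounds, and the source may have more. Where it says the series, first, only, none or still open, it means among the compounds named here.

Measured so far in a functional assay with Homo sapiens as the target; on this read-out higher numbers stand for weaker inhibition and lower numbers for stronger inhibition:
compound 1 `CC(C)[C@H](NC(=O)COc1cccc2ccccc12)C(=O)N[C@@H](CC(=O)O)C(=O)COc1ccc(F)cc1F` gives 17600 nM
compound 2 `CC(C)[C@H](NC(=O)COc1cccc2ccccc12)C(=O)N[C@@H](CC(=O)O)C(=O)COc1cc(F)c(F)cc1F` gives 16700 nM
compound 3 `CC(C)[C@H](NC(=O)COc1cccc2ccccc12)C(=O)N[C@@H](CC(=O)O)C(=O)COc1c(F)c(F)c(F)c(F)c1F` gives 8890 nM

The steps of a 2.0-fold lower number from compound 1 to compound 3 (0.30 log units; within the scatter) and a 1.9-fold lower number from compound 2 to compound 3 (0.27 log units; within the scatter) leave compound 3 level with the other two, and a 1.1-fold lower number from compound 1 to compound 2 (0.02 log units; within the scatter) separates nothing either.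

In compound 4 `CC(C)[C@H](NC(=O)COc1cccc2ccccc12)C(=O)N[C@@H](CC(=O)O)C(=O)COc1ccc([N+](=O)[O-])cc1F` 2-fluoro-4-nitrophenyl stands in place of 2,3,4,5,6-pentafluorophenyl on an oxygen on a saturated carbon, the full difference from compound 3 being 2-fluoro-4-nitrophenyl in place of 2,3,4,5,6-pentafluorophenyl on an oxygen on a saturated carbon in the counted terms.

All three measured steps alter this same phenyl group, and none leaves the scatter. Among the measured compounds shown here, no measured compound carries 2-fluoro-4-nitrophenyl, so the evidence for this change is indirect.

For the measured compounds named here, with measured steps on this group no larger than a 2.0-fold lower number from compound 1 to compound 3 (0.30 log units; within the scatter) on the numbers so far, no step beyond the scatter is expected in this assay for this change, and the estimated step is a 1.3-fold higher number from compound 3 to compound 4 (0.13 log units; within the scatter) at its centre.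

The estimated value for compound 4 is 12000 nM with an expected range of 5000 nM to 28000 nM for this measurement.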

Compound 4, half-maximal inhibitory concentration: 15800 nM
The estimate for compound 4 lay 1.3-fold (0.12 log units) below the measured number, and the stated range covers the measured number.
By their numbers in this assay, from the lowest: compounds 3, 4, 2 and 1 (each within the scatter of the next).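

In this assay, 2-fluoro-4-nitrophenyl on an oxygen on a saturated carbon gives a 1.8-fold higher number from compound 3 to compound 4 (0.25 log units; within the scatter), a 1.1-fold lower number from compound 2 to compound 4 (0.02 log units; within the scatter) and a 1.1-fold lower number from compound 1 to compound 4 (0.05 log units; within the scatter), all within the scatter. The earlier compounds shown here varied only the number and placing of fluoro groups on the phenyl, whereas compound 4 shows that a nitro group, with the hydrogen-bond acceptors counted for 2-fluoro-4-nitrophenyl and absent from 2,3,4,5,6-pentafluorophenyl, also leaves the number level with the others. All four compounds therefore remain unseparated at this position.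

On these data alone, whether an amine, a carboxylic acid or a saturated ring in place of the phenyl would give a step beyond the scatter stays open. Also open, as far as these compounds go, is whether a phenyl carrying a nitro group but no fluoro would stay level with these four compounds. No measurement bearing on the reason for this result is available.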